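A few compounds are considered here, and "the series" means these few. Any claim that something is new, unique, unknown or untested is made for them only; others in the source may bear on it.

Of the compounds shown here, three built on a shared core have so far been tested in a functional assay on Raji cells (Homo sapiens) for cytotoxicity, with a stated time of 72 h (a lower number here means that less compound is needed, a higher number that more compound is needed for the effect), and none of them has given a true number. Compound 1 (`C=C[C@@](C)(/C=C/c1ccc(OS(=O)(=O)c2ccc(C)cc2)cc1)CCC=C(C)C`) reads > 26000 nM, which is a limit of the assay. Compound 2 (`C=C[C@](C)(CCCC(C)C)CCc1ccc(O)cc1`) reads > 26000 nM, again a limit. Compound 3 (`C=C[C@@](C)(/C=C/c1ccc(O)cc1)CCC1OC1(C)C`) reads > 22500 nM, also a limit. Compound 3 therefore has no measured potency to set against the other two, and the three results cannot be ranked.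

Compound 4 (`C=C[C@@](C)(/C=C/c1ccc(O)cc1)CC/C=C(\C)CO`) has not yet been measured. It has the same atoms as compound 3, joined differently: 2-(hydroxymethyl)prop-1-en-1-yl in place of 3,3-dimethyloxiran-2-yl on a saturated chain carbon, three bonds along the chain from two double-bonded chain carbons. In plain terms, 2-(hydroxymethyl)prop-1-en-1-yl stands in place of 3,3-dimethyloxiran-2-yl, so the three-membered ring is gone and a double bond takes its place.

Within the data shown here, no measured pair in this small set shows what such a change does. The expectation rests on compound 3, whose reading of > 22500 nM is a limit. No shift beyond the usual scatter is expected in this assay, in either direction, and the expected change is a step that the limit leaves unreadable from compound 3 to compound 4. For compound 4 the estimate is 25000 nM, with an expected range from 12000 nM to 45000 nM.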

Compound 4, half-maximal effective concentration: > 26000 nM
Compound 4: only a limit was reported; the forecaster's own chance of this, stated with the estimate: 75%; middle value at least 1.0-fold (0.01 log units) away from the limit.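

Among these compounds, compound 3 and compound 4 each give only a limit in this assay, so no step from one to the other can be read. The compounds shown leave open whether anything built on this shared core gives a true number in this assay, and what replacing 3,3-dimethyloxiran-2-yl with 2-(hydroxymethyl)prop-1-en-1-yl does to that number.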